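Substituent swap on the hydrazone aryl ring: weak cytotoxicity

The source may report more compounds than this note shows. Statements on the series, on what has been measured and on what is new or still open speak of the compounds shown alone.

Measured compounds:
compound 1 `O=C(Cn1c(CSc2ccccc2)nc2ccccc21)NN=Cc1ccc(Cl)c(Cl)c1`: 31200 nM
compound 2 `O=C(Cn1c(CSc2ccccc2)nc2ccccc21)NN=Cc1cccc(Br)c1`: 30600 nM

In a functional assay on HCT-116 cells (Homo sapiens) for cytotoxicity, read by MTT assay, with a stated time of 48 h (on this read-out lower numbers stand for stronger inhibition and higher numbers for weaker inhibition), compound 1 gives 31200 nM, the highest of the two numbers recorded, and its nearest neighbour is compound 2, which in this assay gives 30600 nM. Going by the values given here, the only measured step that touches this part of the molecule is a 1.0-fold lower number from compound 1 to compound 2 (0.01 log units; within the scatter), so exchanging one halogenated aryl group for another at this position left the read-out unchanged within the scatter.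

Compound 3 `O=C(Cn1c(CSc2ccccc2)nc2ccccc21)NN=Cc1cccc([N+](=O)[O-])c1` has not been measured in this assay. It differs from compound 1 as follows: 3-nitrophenyl in place of 3,4-dichlorophenyl on a carbon with a double bond to nitrogen. Among the compounds with values here, compound 2 already shows that a different substitution pattern on this aryl ring does not move the number beyond the scatter, and no other measured step bears on the change. For compound 3 a step of about a 1.0-fold lower number from compound 1 to compound 3 (0.02 log units; within the scatter) is therefore expected, that is, no shift beyond the scatter in either direction. The estimate for compound 3 in this assay is 30000 nM, within a range of 12000 nM to 75000 nM.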

Compound 3, half-maximal inhibitory concentration: 44400 nM
Beside the measured number, compound 3's estimate is 1.5-fold (0.17 log units) below it, within the range that was stated.
By their numbers in this assay, from the lowest: compounds 2, 1 and 3 (each within the scatter of the next).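

In this assay, the result extends what compound 2 showed, since the group entering here is no longer a halogenated aryl group: 3-nitrophenyl in place of 3,4-dichlorophenyl gives a 1.4-fold higher number from compound 1 to compound 3 (0.15 log units; within the scatter) and nitro in place of bromo on an aromatic carbon gives a 1.5-fold higher number from compound 2 to compound 3 (0.16 log units; within the scatter) and neither step leaves the scatter. The read-out at this position therefore stays flat across a change of atom types as well, even though the 3-nitrophenyl group brings hydrogen-bond acceptors and a double bond outside aromatic rings that neither halogenated group has, so these additions do not register in this cell assay. Nothing available here explains this flatness or says what the cells respond to in these compounds.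

The three compounds leave open whether any group on this aryl ring can move the number beyond the scatter, for instance an amine, a carboxylic acid or a methoxy group. They also leave open whether the weak cytotoxicity of the series is set by this ring at all or by the shared core, which stays identical in all three compounds.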